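The source may report more compounds than this note shows. Statements on the series, on what has been measured and on what is new or still open speak of the compounds shown alone.

In an in vitro ADME assay on microsomes from Gut (Homo sapiens) for metabolic stability, using NADPH (on this read-out higher numbers stand for fast clearance and lower numbers for slow clearance), compound 1 (`CC(C)(CO)CNC(=O)c1cc2cc(C#N)ccc2n1Cc1cc(Cl)cc(Cl)c1`) gives < 6 mL.min-1.g-1 as a limit of the assay, not as a number. Compound 2 (`Cc1ccc(C)c(Cn2c(C(=O)NCC(C)(C)CO)cc3cc(C#N)ccc32)c1`) gives < 6 mL.min-1.g-1 as a limit too, so it has no number of its own. Taken together, the record shows the limit of < 6 mL.min-1.g-1 in this assay, at which 2 of the 2 values shown sit, and nothing more. Compound 3 (`CCCOc1cccc(Cn2c(C(=O)NCC(C)(C)CO)cc3cc(C#N)ccc32)c1`) differs from compound 2 on a saturated chain carbon bound to an aromatic nitrogen, where 3-propoxyphenyl stands in place of 2,5-dimethylphenyl (3-propoxyphenyl in place of 2,5-dimethylphenyl on a saturated chain carbon bound to an aromatic nitrogen), with the rest of the structure shared. For the measured compounds named here, the one measured step at this place is a step that the two limits leave unreadable from compound 1 to compound 2 and it gives no size to carry over. Going by the values given here, no measured step therefore sizes this change, and the expectation rests on the limit alone. Compound 2 reads < 6 mL.min-1.g-1 in this assay as a limit, so any readable change could only show toward faster clearance. The expected move is an at least 1.3-fold higher number from compound 2 to compound 3 (0.12 log units; that floor lies within the scatter) as an estimate, small and toward faster clearance if it shows at all. Compound 3 is estimated at 8 mL.min-1.g-1 in this assay with an expected range from 3 mL.min-1.g-1 to 25 mL.min-1.g-1 and a real chance of another limit.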

Compound 3, intrinsic clearance in microsomes: 13 mL.min-1.g-1
Compound 3: middle estimate off by 1.6-fold (0.21 log units), on the low side; measured number inside the range.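

In this assay, the place on a saturated chain carbon bound to an aromatic nitrogen now shows that a change there can register on the read-out; the earlier pair could not show this, as the step between compound 1 and compound 2 cannot be read. Putting 3-propoxyphenyl in place of 2,5-dimethylphenyl gives an at least 2.1-fold higher number from compound 2 to compound 3 (0.33 log units; beyond the scatter), and putting it in place of 3,5-dichlorophenyl gives an at least 2.1-fold higher number from compound 1 to compound 3 (0.33 log units; beyond the scatter), both floors beyond the scatter, so the true steps may be larger. Compound 3 is the only one of the three compounds with a number of its own rather than a limit of the assay: the limit of < 6 mL.min-1.g-1 in this assay, at which 2 of the 3 values shown sit.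

The compounds shown do not separate the parts of the change, as 3-propoxyphenyl differs from 2,5-dimethylphenyl in its oxygen, in its chain and in where its substituent stands on the ring. A phenyl ring carrying a propyl chain without the oxygen, a methoxy group or a longer butoxy chain would be needed to tell whether the step follows the oxygen, the chain length or the substitution pattern.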